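A few compounds are considered here, and "the series" means these few. Any claim that something is new, unique, unknown or untested is made for them only; others in the source may bear on it.

Compound 2 `O=C(CSc1nc2cccnc2[nH]1)Nc1ccc(Cl)cc1` carries a 4-chlorophenyl on the amide-type nitrogen. In an assay on isolated protein for inhibition of Ectonucleotide pyrophosphatase/phosphodiesterase family member 1 (Homo sapiens), tested at 10 uM (on this read-out higher numbers stand for more inhibition at the one concentration tested (going by the name of the read-out) and lower numbers for less inhibition), compound 2 gives 17%, the lowest of the two numbers available; compound 1 `O=C(CSc1nc2cccnc2[nH]1)Nc1ccccc1Cl` gives 19%, and the step of a number 2 percentage points lower from compound 1 to compound 2 (within the scatter) lies within the scatter. Compound 3 `O=C(CSc1nc2cccnc2[nH]1)Nc1ccc(F)cc1` differs from compound 2 by fluoro in place of chloro on an aromatic carbon. Among the compounds with values here, no measured step swaps one halogen for another, so the single known step offers no direct guide, and no step beyond the scatter is expected. Compound 3 is therefore expected to give 15%, between 5% and 28%, which would be a step of a number 2 percentage points lower from compound 2 to compound 3 (within the scatter).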

Compound 3, a percentage reported as inhibition, at one concentration (the size of the read-out at that concentration, not a potency): 30%
Compound 3: the middle estimate sits 15 percentage points below what was measured, outside the stated range (above it).
By their numbers in this assay, from the lowest: compounds 2 and 1 (each within the scatter of the next); then compound 3.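

In this assay, within the data shown here, the halogen at this place on the ring does matter: fluoro in place of chloro gives a number 13 percentage points higher from compound 2 to compound 3 (beyond the scatter), the first step beyond the scatter. The change from the other chlorophenyl compound gives a number 11 percentage points higher from compound 1 to compound 3 (beyond the scatter), so the 4-fluorophenyl group stands clear of both chlorophenyl groups. Nothing available explains these steps.

On these data alone, whether a bromo, a methoxy or an amine at the same place would give a higher or lower number stays open. So does the result for a phenyl ring carrying no halogen at all.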